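Extending the urea chain of compound 3 toward a piperidine

The compounds below may be only part of what the source reports. "The series", "measured", "known", "first", "only" and "open" are said of these compounds alone.

For the measured compounds named here, in a functional assay on HCT-116 cells (Homo sapiens) for cytotoxicity, read by MTT assay, with a stated time of 72 h (on this read-out lower numbers stand for stronger inhibition and higher numbers for weaker inhibition), compound 3 `CNC(=O)Nc1nc2ccc(-c3cnc(OC)c(NS(=O)(=O)c4ccc(F)cc4)c3)cn2n1` gives 180 nM, the second highest of the three numbers measured so far. Its nearest neighbour is compound 1 `CCCNC(=O)Nc1nc2ccc(-c3cnc(OC)c(NS(=O)(=O)c4ccc(F)cc4)c3)cn2n1`, which gives 150 nM in this assay, so that a 1.2-fold higher number from compound 1 to compound 3 (0.08 log units; within the scatter). Its furthest neighbour is compound 2 `COc1ncc(-c2ccc3nc(NC(=O)N4CCCC4)nn3c2)cc1NS(=O)(=O)c1ccc(F)cc1`, which gives 1290 nM, and a 7.2-fold lower number from compound 2 to compound 3 (0.86 log units; beyond the scatter). Compound 4 `COc1ncc(-c2ccc3nc(NC(=O)NCCN4CCCCC4)nn3c2)cc1NS(=O)(=O)c1ccc(F)cc1` differs from compound 3 by (piperidin-1-yl)methyl in place of hydrogen on a saturated chain carbon bound to an amide-type nitrogen. This change sits on the saturated chain carbon, where a 1.2-fold higher number from compound 1 to compound 3 (0.08 log units; within the scatter); the larger step of an 8.6-fold higher number from compound 1 to compound 2 (0.93 log units; beyond the scatter) concerned the carbonyl carbon and bears less directly. Compound 4 is therefore expected to show a 1.4-fold higher number from compound 3 to compound 4 (0.14 log units; within the scatter), with an estimated 250 nM and a range from 80 nM to 800 nM.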

Compound 4, half-maximal inhibitory concentration: 150 nM
Compound 4: the middle estimate sits 1.7-fold (0.22 log units) above what was measured, within the range that was stated.
By their numbers in this assay, from the lowest: compounds 1, 4 and 3 (each within the scatter of the next); then compound 2.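

Placing (piperidin-1-yl)methyl on a saturated chain carbon bound to an amide-type nitrogen leaves the number within the scatter in this assay, with a 1.2-fold lower number from compound 3 to compound 4 (0.08 log units; within the scatter). Piperidin-1-yl in place of the terminal methyl of the propyl chain likewise gives no change at the digits printed from compound 1 to compound 4 (within the scatter), so this chain position carries a much larger group with no change beyond the scatter, while the urea with pyrrolidin-1-yl on the carbonyl carbon stands apart, with an 8.6-fold lower number from compound 2 to compound 4 (0.93 log units; beyond the scatter). No measurement shown explains these numbers. As far as these compounds go, whether a morpholine, a carboxylic acid or a longer chain at this position would keep the number remains open.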